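The source may hold more compounds than are shown below. What is called first, only, known or untested is meant among the compounds shown, and "the series" means these compounds.

Series notes. Compound 1 `CCOC(=O)/C(O)=C/C(=O)c1cn(Cc2ccc(F)c(F)c2)c2cccc(OC)c12` gives 125000 nM in an ADME assay on MT4 cells (Homo sapiens) for cytotoxicity, read by MTT assay; on this read-out higher numbers stand for lower toxicity in this test and lower numbers for higher toxicity in this test. Compound 2 `CCOC(=O)/C(O)=C/C(=O)c1cn(Cc2cc(F)cc(F)c2)c2cccc(OC)c12` gives 34700 nM in this assay, and compound 3 `CCOC(=O)/C(O)=C/C(=O)c1cn(Cc2cccc(F)c2F)c2cccc(OC)c12` gives 21100 nM in this assay, the lowest of the three numbers; its nearest neighbour stands at a 1.6-fold lower number from compound 2 to compound 3 (0.22 log units; within the scatter) and its furthest at a 5.9-fold lower number from compound 1 to compound 3 (0.77 log units; beyond the scatter). Compound 4 `CCOC(=O)/C(O)=C/C(=O)c1cn(Cc2ccc(F)cc2F)c2cccc(OC)c12` differs from compound 3 by 2,4-difluorophenyl in place of 2,3-difluorophenyl on a saturated chain carbon bound to an aromatic nitrogen. Among the measured compounds shown here, the steps that bear on this change are the other rearrangements of the two fluorines on that ring: a 3.6-fold lower number from compound 1 to compound 2 (0.56 log units; beyond the scatter), a 5.9-fold lower number from compound 1 to compound 3 (0.77 log units; beyond the scatter) and a 1.6-fold lower number from compound 2 to compound 3 (0.22 log units; within the scatter), all modest or within the scatter. For compound 4 a step in this assay of a 1.4-fold higher number from compound 3 to compound 4 (0.15 log units; within the scatter) is therefore expected, with no firm direction. The estimate for compound 4 is 30000 nM, with a range from 12000 nM to 75000 nM.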

Compound 4, half-maximal cytotoxic concentration: 65500 nM
The estimate for compound 4 lay 2.2-fold (0.34 log units) below the measured number; measured number inside the range.
By their numbers in this assay, from the lowest: compounds 3, 2, 4 and 1 (each within the scatter of the next, the first and the last beyond it).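

In this assay the change to 2,4-difluorophenyl gives a 3.1-fold higher number from compound 3 to compound 4 (0.49 log units; beyond the scatter) and so separates two groups that share the same atoms. The steps of a 1.9-fold higher number from compound 2 to compound 4 (0.28 log units; within the scatter) and a 1.9-fold lower number from compound 1 to compound 4 (0.28 log units; within the scatter) both stay within the scatter, which places compound 4 in the middle of a continuous run with no clean break into two sets. Nothing at hand explains these differences.

The compounds shown carry only difluorophenyl groups at this place, so how a plain phenyl, a dichlorophenyl or a longer chain before the ring would read in this assay stays open.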